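Notes on the step from compound 2 to compound 3

The source may hold more compounds than are shown below. What is called first, only, known or untested is meant among the compounds shown, and "the series" means these compounds.

Of the compounds shown here, two have numbers so far in an ADME assay on HepG2 cells (Homo sapiens) for cytotoxicity; on this read-out lower numbers stand for higher toxicity in this test and higher numbers for lower toxicity in this test. Compound 1 (`CSc1cccc(N(C(=O)c2cc3ccc(C(F)(F)F)cc3[nH]2)[C@H](C)C(=O)NC2CCCC2)c1`) gives 15000 nM, and compound 2 (`CSc1cccc(N2C(=O)CN(c3cc(C(F)(F)F)ccc3C)CC2C(=O)NC2CCCC2)c1`) gives 10000 nM. These values lie within the scatter of each other, so compound 2 stands level with compound 1 on the numbers available.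

Compound 3 (`CSc1cccc(N2C(=O)CN(c3cncc(C(F)(F)F)c3)CC2C(=O)NC2CCCC2)c1`) differs from compound 2 in one place: 5-(trifluoromethyl)pyridin-3-yl in place of 2-methyl-5-(trifluoromethyl)phenyl on an amine nitrogen in a ring. Here 5-(trifluoromethyl)pyridin-3-yl stands in place of 2-methyl-5-(trifluoromethyl)phenyl on an amine nitrogen in a ring, two ring bonds from the ring atom that bears a cyclopentylcarbamoyl group.

Within the data shown here, no pair of measured compounds isolates a change at this place, so the size of this step has no direct guide. In this assay no step beyond the scatter is expected, and neither direction is favoured. This expectation rests only on compound 1 at 15000 nM and compound 2 at 10000 nM, two different structures with values within the scatter. The estimated step is a 1.1-fold higher number from compound 2 to compound 3 (0.04 log units; within the scatter). For compound 3 the expected value is 11000 nM, with an estimated range of 5000 nM to 25000 nM.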

Compound 3, half-maximal cytotoxic concentration: > 50000 nM
Compound 3 gave a limit, no number; the forecaster's own chance of this, stated with the estimate: 30%; middle value at least 4.5-fold (0.65 log units) from the limit.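

In this assay, among these compounds, the replacement of 2-methyl-5-(trifluoromethyl)phenyl by 5-(trifluoromethyl)pyridin-3-yl on the amine nitrogen in the ring gives an at least 5.0-fold higher number from compound 2 to compound 3 (0.69 log units; beyond the scatter), the first step that isolates this place and one that lies beyond the scatter. Two things change together in this step: the methyl group leaves, and the aromatic ring takes up a hetero atom and with it a hydrogen-bond acceptor, so the step cannot be assigned to either part alone. The value of compound 3 is a limit of the assay and not a number, so the step has a lower bound only: the limit of > 50000 nM in this assay, at which 1 of the 3 values shown sits.

Going by these compounds, what a phenyl ring bearing trifluoromethyl alone would give at this place stays open, and with it the shares of the step that belong to the methyl group and to the ring nitrogen. Also open, on these data alone, is whether a pyridinyl ring bearing a nitrile in place of trifluoromethyl would keep the step, and how far the true value of compound 3 lies from its limit.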